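A few compounds are considered here, and "the series" means these few. Any claim that something is new, unique, unknown or untested is made for them only; others in the source may bear on it.

For the measured compounds named here, in a functional assay for inhibition, with Rattus norvegicus as the target (on this read-out lower numbers stand for stronger inhibition and higher numbers for weaker inhibition), only two compounds have been measured so far. Compound 1 (`CC(/N=c1\c(O)c(O)\c1=N/c1ccc(Br)cc1)C(C)(C)C`) gives 1260 nM, and compound 2 (`CC(=O)c1ccc(/N=c2\c(O)c(O)\c2=N/C(C)C(C)(C)C)cc1`) gives 21200 nM, the higher of the two numbers and thus the weaker inhibition. Compound 3 (`CC(/N=c1\c(O)c(O)\c1=N/c1ccc(S(C)(=O)=O)cc1)C(C)(C)C`) carries methylsulfonyl in place of acetyl on an aromatic carbon, para to a large group: methylsulfonyl in place of acetyl on an aromatic carbon. Going by the values given here, only one measured step bears on this change: acetyl in place of bromo on that same carbon, a 17-fold higher number from compound 1 to compound 2 (1.23 log units; beyond the scatter), a large step beyond the scatter. Among the compounds with values here, no measured pair exchanges acetyl for methylsulfonyl, so that step gives no direct guide to direction. Little change beyond the scatter is therefore expected, although the range stays wide. The expected step is a 1.4-fold lower number from compound 2 to compound 3 (0.15 log units; within the scatter). The estimated value for compound 3 is 15000 nM, expected to fall between 3000 nM and 50000 nM.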

Compound 3, half-maximal inhibitory concentration: > 30000 nM
Compound 3: a limit, no number; the forecaster's own chance of this, stated with the estimate: 15%; middle value at least 2.0-fold (0.30 log units) away from the limit.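

Compound 3 gives only a limit of the assay, not a number: the limit of > 30000 nM in this assay, at which 1 of the 3 values shown sits. In this assay, methylsulfonyl in place of acetyl on this aromatic carbon gives an at least 1.4-fold higher number from compound 2 to compound 3 (0.15 log units; that floor lies within the scatter), so this exchange brings no lower number, yet its floor alone does not separate the two groups. Methylsulfonyl in place of bromo gives an at least 23-fold higher number from compound 1 to compound 3 (1.37 log units; beyond the scatter), a large step that makes methylsulfonyl the second group on this carbon, after acetyl, to stand well on the weaker side of bromo.

Going by these compounds, how far compound 3 lies past its limit stays open, and with it whether the true gap between acetyl and methylsulfonyl exceeds the scatter. Also open, on these data alone, is whether an amine, a methyl group or chloro on this carbon would keep the number near that of compound 1.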